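Capping the acid of compound 2

This account rests on a few compounds, and the source may have more. Where it says the series, first, only, none or still open, it means among the compounds named here.

Compound 1 (`COc1ccc(/C=C\c2cc(OC)c(OC)c(OC)c2)cc1OCc1ccc(CNC(C)(C)C(=O)O)cc1`) reads > 10000 nM in a functional assay on HeLa cells (Homo sapiens) for antiproliferative activity, read by CCK-8 assay, with a stated time of 48 h (on this read-out lower numbers stand for stronger inhibition and higher numbers for weaker inhibition), and that reading is a limit. Going by the values given here, compound 2 (`COc1ccc(/C=C\c2cc(OC)c(OC)c(OC)c2)cc1OCc1ccc(CN2CCCCC2C(=O)O)cc1`) gives 14200 nM in this assay as the only true number so far. Among the compounds with values here, the one measured step is a step that the limit leaves unreadable from compound 1 to compound 2 and so offers no size to carry over. Compound 3 (`COc1ccc(/C=C\c2cc(OC)c(OC)c(OC)c2)cc1OCc1ccc(CN2CCCCC2C(=O)NCCNC(=O)OC(C)(C)C)cc1`) has (2-((tert-butoxycarbonyl)amino)ethyl)amino in place of hydroxy on a carbonyl carbon. A move to stronger inhibition is expected only loosely, from the weak reading of compound 2 at 14200 nM and the loss of that hydroxy. The expected size is a 7.1-fold lower number from compound 2 to compound 3 (0.85 log units; beyond the scatter) on this thin evidence. In this assay compound 3 is estimated at 2000 nM (expected range 150 nM to 14000 nM).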

Compound 3, half-maximal inhibitory concentration: 2000 nM
The estimate for compound 3 equals the measured number at the digits printed, within the range that was stated.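

At the carbonyl carbon, (2-((tert-butoxycarbonyl)amino)ethyl)amino in place of hydroxy gives a 7.1-fold lower number from compound 2 to compound 3 (0.85 log units; beyond the scatter) in this assay. This pair shows that the hydroxy of the carboxylic acid can be replaced at this position without loss, and that the larger amide reads stronger. Compound 1 remains a limit, so the step from it cannot be read and this step has no sized step to be set against: the limit of > 10000 nM in this assay, at which 1 of the 3 values shown sits.

The compounds shown leave open whether the change comes from the amide itself or from the tert-butoxycarbonyl group. On these data alone, how a free primary amine at the chain end, or a longer chain, would read also remains open.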